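Thiocarbonyl series on two cores: expectation for compound 4

The source may report more compounds than this note shows. Statements on the series, on what has been measured and on what is new or still open speak of the compounds shown alone.

Measured in a functional assay on HEp-2 cells (Homo sapiens) for antiproliferative activity, read by MTT assay, with a stated time of 72 h; on this read-out lower numbers stand for stronger inhibition and higher numbers for weaker inhibition:
compound 1 `CC(C)N(C(=S)SCc1cc(=O)c2ccc(Cl)cc2o1)C(C)C` gives 22700 nM
compound 2 `O=c1cc(CSC(=S)N2CCOCC2)oc2cc(Cl)ccc12` gives 20600 nM
compound 3 `O=c1c(CSC(=S)N2CCOCC2)coc2ccccc12` gives 4400 nM

Compound 3 stands lowest of the three; its nearest neighbour is compound 2, and the gap between them is beyond the scatter, as is the gap to compound 1. How the core of compound 3 differs from the core of compound 2 is not broken down here.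

One change recurs twice in the set: diisopropylamino in place of morpholin-4-yl on a thiocarbonyl carbon. Between the two measured compounds it gave a 1.1-fold higher number from compound 2 to compound 1 (0.04 log units; within the scatter), a step within the scatter. The same change is now made on the other core, giving the unmeasured compound 4 `CC(C)N(C(=S)SCc1coc2ccccc2c1=O)C(C)C`, with the difference (diisopropylamino in place of morpholin-4-yl on a thiocarbonyl carbon). The place of the change reads the same in both cases.

Because the earlier step was a 1.1-fold higher number from compound 2 to compound 1 (0.04 log units; within the scatter), the step from compound 3 to compound 4 is expected to be small as well, estimated as a 1.1-fold higher number from compound 3 to compound 4 (0.04 log units; within the scatter). For compound 4 in this assay the estimate is 4800 nM, with a plausible range from 2400 nM to 10000 nM. This rests on a single precedent, so the range is kept wide.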

Compound 4, half-maximal inhibitory concentration: 3000 nM
Estimate against measurement, compound 4: 1.6-fold (0.20 log units) above; the measured number falls inside the stated range.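

In this assay, diisopropylamino in place of morpholin-4-yl on a thiocarbonyl carbon gives a 1.5-fold lower number from compound 3 to compound 4 (0.17 log units; within the scatter), so this step also stays within the scatter. The steps on the two cores do not differ measurably, and the exchange carries over between these cores without a detectable shift: the same change on two cores in this assay, a 1.1-fold higher number (0.04 log units; within the scatter) from compound 2 to compound 1 and a 1.5-fold lower number (0.17 log units; within the scatter) from compound 3 to compound 4, 1.6-fold (0.21 log units) apart, within the scatter of two such steps. Going by these compounds alone, this supports treating the two groups as interchangeable at this place on these two cores in this one cell read-out, but with only two pairs, it shows no real effect of either group and does not predict the outcome on any other core.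

The compounds shown leave open whether the same flat result would hold for a group of another kind at this place, such as a piperazine with a free amine hydrogen or a chain ending in a carboxylic acid. They also leave open whether a smaller open-chain amine, such as dimethylamino, would behave like diisopropylamino on both cores.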